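The source may report more compounds than this note shows. Statements on the series, on what has been measured and on what is new or still open speak of the compounds shown alone.

Measured compounds:
Compound 1, `COC(=O)c1cc(=O)c2c(OC)cc(OC)cc2n1C`: > 37900 nM
Compound 2, `COc1ccc(-c2cc(=O)c3c(OC)cc(OC)cc3n2S(=O)(=O)c2ccc(F)cc2)cc1`: > 65500 nM

Both compounds were tested in a functional assay on SUP-B15 cells (Homo sapiens) for antiproliferative activity, with a stated time of 72 h; on this read-out higher numbers stand for an effect only at larger amounts of compound and lower numbers for an effect already at smaller amounts. For compound 1 the result > 37900 nM is a limit of the assay, not a number. For compound 2 the result > 65500 nM is likewise only a limit. So compound 2 stands at the limit of this assay, with no measured number of its own (the limit of > 65500 nM in this assay, at which 1 of the 2 values shown sits), and compound 1 stands at a limit as well (the limit of > 37900 nM in this assay, at which 1 of the 2 values shown sits).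

Compound 3, `COc1ccc(-c2cc(=O)c3c(OC)cc(OC)cc3n2S(=O)(=O)c2ccc(Br)s2)cc1`, has not yet been measured. It differs from compound 2 in one place:
5-bromothiophen-2-yl in place of 4-fluorophenyl on a sulfonyl sulfur
Within the data shown here, no step between two measured compounds exists here to gauge such a change, and both measured values are limits. The expectation is therefore no step beyond the usual scatter, a step that the limit leaves unreadable from compound 2 to compound 3, with compound 3 most likely again reported only as a limit. Compound 3 is estimated at 70000 nM, in a range from 20000 nM to 250000 nM.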

Compound 3, half-maximal effective concentration: > 48200 nM
Compound 3 was reported as a limit; the forecaster's own chance of this, stated with the estimate: 85%; the middle value does not contradict the limit.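

Among these compounds, compound 2 and compound 3 are both reported only as limits, and no step between them can be read for the change from 4-fluorophenyl to 5-bromothiophen-2-yl on the sulfonyl sulfur. The compounds shown leave open at what concentration, if any, either would show an antiproliferative effect.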